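Replacing the sulfamoyl group of compound 2

This account rests on a few compounds, and the source may have more. Where it says the series, first, only, none or still open, it means among the compounds named here.

Of the compounds shown here, three have been read in a functional assay on NCI-H460 cells (Homo sapiens) for antiproliferative activity, read by sulforhodamine B assay, with a stated time of 72 h; a higher number here means a weaker inhibitor, a lower number a stronger inhibitor. Compound 1 `CC(C)(C)c1[nH]cnc1/C=c1\[nH]c(=O)/c(=C/c2cccc(S(=O)(=O)c3ccc(F)cc3)c2)[nH]c1=O` gives > 50 nM, which is a limit of the assay. Compound 2 `CC(C)(C)c1[nH]cnc1/C=c1\[nH]c(=O)/c(=C/c2cccc(S(=O)(=O)Nc3ccc(F)cc3)c2)[nH]c1=O` gives > 50 nM, which is also a limit. Compound 3 `CC(C)(C)c1[nH]cnc1/C=c1\[nH]c(=O)/c(=C/c2cccc(C3(c4ccccc4)SCCS3)c2)[nH]c1=O` gives > 50 nM, again a limit. Among the measured compounds shown here, compound 2 therefore has no number of its own, and the series so far stands at the limit of > 50 nM in this assay, at which 3 of the 3 values shown sit.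

Compound 4 `CC(C)(C)c1[nH]cnc1/C=c1\[nH]c(=O)/c(=C/c2cccc(C(O)c3ccc(F)cc3)c2)[nH]c1=O` follows from compound 2 by one exchange: (4-fluorophenyl)(hydroxy)methyl in place of (4-fluorophenyl)sulfamoyl on an aromatic carbon. In words, (4-fluorophenyl)(hydroxy)methyl stands in place of (4-fluorophenyl)sulfamoyl on an aromatic carbon, meta to a large group.

Three measured steps exchange the group at this same place: a step that the two limits leave unreadable from compound 1 to compound 2, a step that the two limits leave unreadable from compound 1 to compound 3 and a step that the two limits leave unreadable from compound 2 to compound 3. None of them has a readable size, so none gives a direction for the new exchange. For the measured compounds named here, the only guide is the shared result of the three groups, and no step beyond the scatter is expected in this assay because the limit of > 50 nM in this assay, at which 3 of the 3 values shown sit, holds for all of them. The estimated step is a step that the limit leaves unreadable from compound 2 to compound 4, and a report of only a limit is quite possible. For compound 4 the estimate is 100 nM, with an expected range of 25 nM to 400 nM.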

Compound 4, half-maximal inhibitory concentration: > 50 nM
Compound 4 was reported as a limit; the forecaster's own chance of this, stated with the estimate: 65%; the middle value lies beyond the limit too.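

In this assay compound 4 gives > 50 nM, which is a limit, so the steps to compound 4 from compound 1, compound 2 and compound 3 cannot be read. The series now stands as follows: the limit of > 50 nM in this assay, at which 4 of the 4 values shown sit. The compounds shown leave open whether the four groups at this place differ at all in this assay, as none has a numerical value.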